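Swapping the aryl group on a thiazole acetic acid core

The compounds below may be only part of what the source reports. "The series", "measured", "known", "first", "only" and "open" are said of these compounds alone.

Measured so far:
compound 1, `O=C(O)Cc1sc(C(c2ccc(F)cc2)c2ccc(F)cc2)nc1-c1ccnc(F)c1`, 4.7 nM
compound 2, `O=C(O)Cc1sc(C(c2ccc(F)cc2)c2ccc(F)cc2)nc1-c1ccccc1`, 240 nM
compound 3, `O=C(O)Cc1sc(C(c2ccc(F)cc2)c2ccc(F)cc2)nc1-c1ccoc1`, 130 nM

These three compounds share one core and differ only in the aromatic group attached to it. In an in vitro functional assay on HEK285-7 cells for antagonist activity at prostaglandin D2 receptor 2 (Homo sapiens), read by BRET and beta-arrestin recruitment (a higher number here means a weaker inhibitor, a lower number a stronger inhibitor), compound 3 gives 130 nM, the second highest of the three numbers. Its nearest neighbour is compound 2: a 1.8-fold lower number from compound 2 to compound 3 (0.27 log units; within the scatter), so the two cannot be told apart. Its furthest is compound 1: a 28-fold higher number from compound 1 to compound 3 (1.44 log units; beyond the scatter), a clear loss when the 2-fluoropyridin-4-yl group is replaced. The step of a 51-fold higher number from compound 1 to compound 2 (1.71 log units; beyond the scatter) shows the same loss for phenyl.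

Compound 4, `NS(=O)(=O)c1cccc(-c2nc(C(c3ccc(F)cc3)c3ccc(F)cc3)sc2CC(=O)O)c1`, carries a different change at the same position: 3-sulfamoylphenyl in place of furan-3-yl on an aromatic carbon. The measured steps show that swapping this aromatic group can move the number a great deal, as from compound 1, or hardly at all, as between compound 2 and compound 3. Among the measured compounds shown here, no measured step involves a sulfamoyl group, so the direction is uncertain. Compound 4 is expected to land near 50 nM, within 8 nM to 300 nM, in this assay. That estimate means a step of a 2.6-fold lower number from compound 3 to compound 4 (0.41 log units; beyond the scatter), expected to be modest and to favour a lower number.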

Compound 4, half-maximal inhibitory concentration: 710 nM
Beside the measured number, compound 4's estimate is 14-fold (1.15 log units) below it; measured number outside the range, above it.
By their numbers in this assay, from the lowest: compound 1; then compounds 3 and 2 (each within the scatter of the next); then compound 4.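

Adding a sulfamoyl group to the phenyl ring gives a 3.0-fold higher number from compound 2 to compound 4 (0.47 log units; beyond the scatter), so at this position a substituent on the aromatic ring can shift the result, whereas the earlier compounds showed only one ring exchanged for another. The same change weakens inhibition further when set against the other two groups, with a 5.5-fold higher number from compound 3 to compound 4 (0.74 log units; beyond the scatter) and a 150-fold higher number from compound 1 to compound 4 (2.18 log units; beyond the scatter), which makes compound 4 the weakest inhibitor of the four in this assay. Nothing available here explains why the 3-sulfamoylphenyl group raises the number.

From the compounds shown here alone, it remains open whether a simple amine or a carboxylic acid on the phenyl ring would raise the number as well. Also open, going by these compounds, is whether the fluorine or the ring nitrogen matters more in the 2-fluoropyridin-4-yl group, which a plain pyridin-4-yl or a fluorophenyl group could help to separate.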